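Chain Extension and Cytotoxicity in Vero Cells

A few compounds are considered here, and "the series" means these few. Any claim that something is new, unique, unknown or untested is made for them only; others in the source may bear on it.

Four esters share one core. Compound 1 `CCCCCC(=O)OCC(C)(C)CC1=C(O)C(=O)c2ccccc2C1=O` gives 169000 nM in an ADME assay on Vero cells (Chlorocebus sabaeus) for cytotoxicity, read by reporter gene assay, with a stated time of 4 days; on this read-out higher numbers stand for weaker inhibition and lower numbers for stronger inhibition. Compound 2 `CCCCCCC(=O)OCC(C)(C)CC1=C(O)C(=O)c2ccccc2C1=O` gives 99300 nM in this assay, and compound 3 `CCCCCCCCCC(=O)OCC(C)(C)CC1=C(O)C(=O)c2ccccc2C1=O` gives 203000 nM in this assay. Compound 2 differs from compound 1 by methyl in place of hydrogen on a saturated chain carbon, five bonds along the chain from a carbonyl carbon, a change that produced a 1.7-fold lower number from compound 1 to compound 2 (0.23 log units; within the scatter). Compound 3 differs from compound 1 by butyl in place of hydrogen on a saturated chain carbon, five bonds along the chain from a carbonyl carbon, and the step of a 2.0-fold higher number from compound 2 to compound 3 (0.31 log units; beyond the scatter) separates it from compound 2. Compound 4 `CCCCCCCCCCC(=O)OCC(C)(C)CC1=C(O)C(=O)c2ccccc2C1=O` is not yet measured; it differs from compound 3 by methyl in place of hydrogen on a saturated chain carbon, nine bonds along the chain from a carbonyl carbon. This is the same kind of change as that between compound 1 and compound 2, but the place is not the same: five bonds along the chain from a carbonyl carbon in the earlier pair, nine bonds along the chain from a carbonyl carbon here. The step is expected to read a 1.1-fold lower number from compound 3 to compound 4 (0.05 log units; within the scatter) because a 1.7-fold lower number from compound 1 to compound 2 (0.23 log units; within the scatter) lay within the scatter. Compound 4 is thus estimated at 180000 nM, between 90000 nM and 360000 nM.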

Compound 4, half-maximal inhibitory concentration: > 233000 nM
Compound 4: a limit, no number; the forecaster's own chance of this, stated with the estimate: 5%; at least 1.2-fold (0.11 log units) between middle value and limit.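

In this assay compound 4 gives > 233000 nM, which is a limit of the assay and not a number. Methyl in place of hydrogen now gives an at least 1.1-fold higher number from compound 3 to compound 4 (0.05 log units; that floor lies within the scatter), which shows neither that the change carries over from one core to another nor that it fails to: the same change on two cores in this assay, a 1.7-fold lower number (0.23 log units; within the scatter) from compound 1 to compound 2 and an at least 1.1-fold higher number (0.05 log units; that floor lies within the scatter) from compound 3 to compound 4; the limit leaves it open whether they differ Butyl in place of hydrogen gives an at least 2.3-fold higher number from compound 2 to compound 4 (0.37 log units; beyond the scatter), pentyl in place of hydrogen gives an at least 1.3-fold higher number from compound 1 to compound 4 (0.13 log units; that floor lies within the scatter), and the butyl comparison remains just as unsettled: the same change on two cores in this assay, a 1.2-fold higher number (0.08 log units; within the scatter) from compound 1 to compound 3 and an at least 2.3-fold higher number (0.37 log units; beyond the scatter) from compound 2 to compound 4; the limit leaves it open whether they differ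

The compounds shown leave open whether a longer chain would give a number rather than a limit in this assay. Equally open, going by these compounds, is how a chain carrying an amine or a carboxylic acid would read.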